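Trifluoromethyl added to the anilide ring: cytotoxicity expectation

A few compounds are considered here, and "the series" means these few. Any claim that something is new, unique, unknown or untested is made for them only; others in the source may bear on it.

Measured compounds:
compound 1 `O=C(Nc1ccccc1C(F)(F)F)c1cc(Cl)ccc1O` gives 19000 nM
compound 2 `O=C(Nc1cc(C(F)(F)F)ccc1C(F)(F)F)c1cc(Cl)ccc1O` gives 6600 nM
compound 3 `O=C(Nc1ccc(F)cc1)c1cc(Cl)ccc1O` gives 17000 nM

All three values come from an ADME assay on cells (Macrophage, Mus musculus) for cytotoxicity, read by resazurin assay, with a stated time of 3 days; a lower number here means a stronger inhibitor, a higher number a weaker inhibitor. Compound 1 and compound 3 share a core whose difference is not broken down here; their values lie within the usual scatter of each other, so no order between them can be read. Compound 2 differs from compound 1 by trifluoromethyl in place of hydrogen on an aromatic carbon, and this gave a 2.9-fold lower number from compound 1 to compound 2 (0.46 log units; beyond the scatter).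

Compound 4 `O=C(Nc1ccc(F)c(C(F)(F)F)c1)c1cc(Cl)ccc1O` is not yet measured. It differs from compound 3 by trifluoromethyl in place of hydrogen on an aromatic carbon. Among the compounds with values here, this is the same kind of change as the one from compound 1 to compound 2, but the surroundings are not identical: in compound 2 the new group sits para to a trifluoromethyl group, while in compound 4 it sits ortho to a fluoro group. With one prior example only, the expectation rests on that single step of compound 1 to compound 2 a 2.9-fold lower number from compound 1 to compound 2 (0.46 log units; beyond the scatter). A step of about a 2.3-fold lower number from compound 3 to compound 4 (0.36 log units; beyond the scatter) in this assay is therefore expected, with room for the surroundings to shift it. Compound 4 is estimated at 7500 nM, within 3500 nM to 17000 nM.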

Compound 4, half-maximal inhibitory concentration: 5300 nM
Compound 4: middle estimate off by 1.4-fold (0.15 log units), on the high side; measured number inside the range.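

In this assay, putting trifluoromethyl in place of hydrogen on an aromatic carbon gave a 3.2-fold lower number from compound 3 to compound 4 (0.51 log units; beyond the scatter), and this new step can be set directly beside the earlier one: the same change on two cores in this assay, a 2.9-fold lower number (0.46 log units; beyond the scatter) from compound 1 to compound 2 and a 3.2-fold lower number (0.51 log units; beyond the scatter) from compound 3 to compound 4, 1.1-fold (0.05 log units) apart, within the scatter of two such steps. On these two cores, then, the change carried over in both direction and size, even though in compound 4 the new group sits ortho to a fluoro group. Within the data shown here, two steps are still only two examples, so they do not show that the same step would appear on other cores, and they do not explain why the number falls.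

On these data alone, it remains open whether another group in the same place, such as a nitrile, an amine or a carboxylic acid, would give a similar step or whether the step belongs to trifluoromethyl alone. The compounds shown also leave open how the step would behave if the chloro or hydroxyl group they all share were replaced.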